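Swapping a Para Acetyl for Propyl on a Styryl Pyridine

This account rests on a few compounds, and the source may have more. Where it says the series, first, only, none or still open, it means among the compounds named here.

Measured so far:
compound 1, `COc1cccc(/C=C2\CCCN=C2c2cccnc2)c1`, 1180 nM
compound 2, `CC(=O)c1ccc(/C=C2\CCCN=C2c2cccnc2)cc1`, 4490 nM

In an assay on membranes from brain for displacement of a labelled ligand from Neuronal acetylcholine receptor; alpha4/beta2 (Rattus norvegicus), with a stated time of 3 h (on this read-out lower numbers stand for stronger inhibition and higher numbers for weaker inhibition), compound 2 gives the higher of the two numbers shown; compound 1 gives 1180 nM, a gap beyond the usual scatter. Compound 3, `CCCc1ccc(/C=C2\CCCN=C2c2cccnc2)cc1`, differs from compound 2 in one place: propyl in place of acetyl on an aromatic carbon. Within the data shown here, no step between measured compounds resembles this change, so the direction is uncertain; a modest shift toward a lower number, or none beyond the scatter, seems most plausible. Compound 3 is therefore expected to give about 2500 nM, a step of a 1.8-fold lower number from compound 2 to compound 3 (0.25 log units; within the scatter), within a range of 800 nM to 8000 nM.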

Compound 3, inhibition constant: 890 nM
Estimate against measurement, compound 3: 2.8-fold (0.45 log units) above, within the range that was stated.
By their numbers in this assay, from the lowest: compounds 3 and 1 (each within the scatter of the next); then compound 2.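

In this assay, the aromatic carbon para to a large group responds to what sits on it: propyl in place of acetyl gives a 5.0-fold lower number from compound 2 to compound 3 (0.70 log units; beyond the scatter). Both groups have 3 heavy atoms, yet propyl has no oxygen, no double bond and no hydrogen-bond acceptor. No measurement here shows which of these differences matters. Still open, going by these compounds, is how an amine, a carboxylic acid or a longer chain such as butyl would read on this carbon. A lone methoxy or ethyl group there is equally unresolved.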